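A Bulkier Ring Amine in Place of Dimethylamino

The compounds below may be only part of what the source reports. "The series", "measured", "known", "first", "only" and "open" are said of these compounds alone.

Measured so far:
Compound 1, `CCC(=O)Nc1cccc(Oc2nc(Nc3ccc(N(C)C)cc3OC)ncc2Cl)c1`, gives 80.6%.
Compound 2, `CCC(=O)Nc1cccc(Oc2nc(Nc3ccc(N4CCC(OC)CC4)cc3)ncc2Cl)c1`, gives 86.5%.
Compound 3, `CCC(=O)Nc1cccc(Oc2ccnc(Nc3ccc(N4CCN(C)CC4)cc3)n2)c1`, gives 85.6%.

All three numbers come from an assay on isolated protein for inhibition of NUAK family SNF1-like kinase 1 (Homo sapiens), read by ADP-Glo, with a stated time of 60 min, tested at 10 uM, in the presence of a further agent that is not named here; on this read-out higher numbers stand for more inhibition at the one concentration tested (going by the name of the read-out) and lower numbers for less inhibition. Compound 1 gives the lowest of the three numbers, yet its gap to compound 3 and its gap to compound 2 both lie within the scatter of repeated measurements, so these three compounds cannot be told apart on the present data; none can be called stronger or weaker than another.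

Compound 4, `CCC(=O)Nc1cccc(Oc2nc(Nc3ccc(N4CCC(C)CC4)cc3OC)ncc2Cl)c1`, has not yet been measured. It differs from compound 1 in one place: 4-methylpiperidin-1-yl in place of dimethylamino on an aromatic carbon. The group that enters is a ring amine, and ring amines of this kind are already carried by compound 2 and compound 3, both of which give numbers within the scatter of the number for compound 1.

Among the compounds with values here, no step between two measured compounds is known, so there is no measured step to lean on. The expectation for the step of a number 3.4 percentage points higher from compound 1 to compound 4 (within the scatter) is none beyond the scatter, in either direction. Compound 4 is therefore estimated to give 84%, with a likely range from 70% to 94%.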

Compound 4, a percentage reported as inhibition, at one concentration (the size of the read-out at that concentration, not a potency): 9.2%
The estimate for compound 4 lay 74.8 percentage points above the measured number; the whole stated range lies above it.
By their numbers in this assay, from the lowest: compound 4; then compounds 1, 3 and 2 (each within the scatter of the next).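

This step shows that the spot para to a large group and meta to a methoxy group does not accept every amine alike: in this assay, putting 4-methylpiperidin-1-yl in place of dimethylamino gives a number 71.4 percentage points lower from compound 1 to compound 4 (beyond the scatter), a drop far larger than the usual scatter. The counted differences are few, as the group that leaves has 3 heavy atoms and no ring, the group that enters has 7 heavy atoms and one six-membered non-aromatic ring, and the counts of hydrogen-bond donors and acceptors and the net charge stay the same. No measurement here explains why this change has so large an effect.

The ring amines of compound 2 and compound 3 stand on compounds that differ from compound 4 in more than one place, so they cannot show whether the ring, the added methyl or the total size of the group matters here. A plain piperidin-1-yl or an open-chain diethylamino on the core of compound 1 would help to separate these possibilities.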